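Capping the Amino Group of Compound 1 with Methylsulfonyl

This account rests on a few compounds, and the source may have more. Where it says the series, first, only, none or still open, it means among the compounds named here.

Compound 1 `Cc1cc2c(c(N)nn2C)c(=O)[nH]1` was tested in an assay on isolated protein for inhibition of RAC-alpha serine/threonine-protein kinase (Homo sapiens), read by mobility shift assay, tested at 30 uM (a lower number here means less inhibition, a higher number more inhibition at the concentration tested (going by the name of the read-out)), where compound 1 gives 11%. Within the data shown here, the only other measured compound, compound 2 `Cn1nc(N)c2c(=O)[nH]c(-c3ccccc3)cc21`, carries phenyl in place of methyl on an aromatic carbon; in this assay compound 2 gives 8%. The step of a number 3 percentage points lower from compound 1 to compound 2 (within the scatter) lies within the scatter, so compound 1 and compound 2 stand level, and both inhibit the enzyme only weakly at the concentration tested.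

Compound 3 `Cc1cc2c(c(NS(C)(=O)=O)nn2C)c(=O)[nH]1` differs from compound 1 in one place: methylsulfonyl in place of hydrogen on a nitrogen on an aromatic ring. Among the measured compounds shown here, no measured step touches this position; the single measured step, a number 3 percentage points lower from compound 1 to compound 2 (within the scatter), changes a group on an aromatic carbon, not on the nitrogen, and it was itself within the scatter. For the measured compounds named here, there is therefore no measured step that bears directly on the change from compound 1 to compound 3, and the two numbers seen so far give no sign that this core responds strongly to substitution. The expected step is a number 1 percentage points lower from compound 1 to compound 3 (within the scatter), that is, none beyond the scatter. For compound 3 in this assay the estimate is 10%, with a range from 0% to 30%.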

Compound 3, a percentage reported as inhibition, at one concentration (the size of the read-out at that concentration, not a potency): 1%
Beside the measured number, compound 3's estimate is 9 percentage points above it, within the range that was stated.
By their numbers in this assay, from the lowest: compounds 3, 2 and 1 (each within the scatter of the next).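

Among these compounds, this is the only measured change at the nitrogen on the aromatic ring: going from amino to methanesulfonamido, with methylsulfonyl in place of hydrogen, gives a step in this assay that reads as a number 10 percentage points lower from compound 1 to compound 3 (within the scatter). The position therefore takes this group with no change beyond the usual scatter, but that is a limited finding, since compound 1 gives only 11%, which leaves the assay little room to show a loss of inhibition. Nothing at hand explains the result or tells what this group does at this position.

Still open, going by these compounds, is whether another group on this nitrogen, such as acetyl, methyl or phenylsulfonyl, would raise inhibition clearly above this weak level. Also open, on these data alone, is whether methylsulfonyl on the same nitrogen of compound 2, which carries phenyl in place of methyl on an aromatic carbon, would give a step of similar size, which would show whether the two changes act independently of each other.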